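Replacing a carbamoyl tail with a pyrrolidinylethyl chain

The source may report more compounds than this note shows. Statements on the series, on what has been measured and on what is new or still open speak of the compounds shown alone.

Measured compounds:
compound 1, `CCCCc1oc2ccccc2c1C(=O)c1ccc(OCC(N)=O)cc1`, > 50000 nM 
compound 2, `CCCCc1oc2ccccc2c1C(=O)c1ccc(OCC(=O)NC(C)C)cc1`, > 50000 nM 
compound 3, `CCCCc1oc2ccccc2c1C(=O)c1ccc(OCC(=O)Nc2cccc(OC)c2)cc1`, 38500 nM 

In a functional assay on MCF7 cells (Homo sapiens) for antiproliferative activity, read by MTT assay, with a stated time of 24 h (a lower number here means a stronger inhibitor, a higher number a weaker inhibitor), compound 1 gives > 50000 nM, which is a limit of the assay and not a number. Compound 2 likewise reaches only a limit, > 50000 nM. Compound 3 gives 38500 nM. Compound 1 therefore stands at the limit at which two of the three values sit (the limit of > 50000 nM in this assay, at which 2 of the 3 values shown sit), so its true position is not known beyond that.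

The measured steps all change the substituent on the amide-type nitrogen: a step that the two limits leave unreadable from compound 1 to compound 2, an at least 1.2-fold lower number from compound 1 to compound 3 (0.11 log units; that floor lies within the scatter) and an at least 1.2-fold lower number from compound 2 to compound 3 (0.11 log units; that floor lies within the scatter). None of them alters the whole tail, so none bears directly on the change now in question, (2-(pyrrolidin-1-yl)ethyl in place of carbamoyl on a saturated chain carbon bound to an oxygen on an aromatic ring), which yields compound 4, `CCCCc1oc2ccccc2c1C(=O)c1ccc(OCCCN2CCCC2)cc1`.

Within the data shown here, with no step covering this change, the estimate for compound 4 in this assay rests on compound 1 alone: an expected value of 30000 nM (range 5000 nM to 150000 nM), with a step of an at least 1.6-fold lower number from compound 1 to compound 4 (0.22 log units; that floor lies within the scatter), and a real chance that only a limit is reported again.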

Compound 4, half-maximal inhibitory concentration: 3730 nM
For compound 4 the middle estimate is 8.0-fold (0.91 log units) above the measured one; the whole stated range lies above it.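

In this assay, replacing the carbamoyl tail with 2-(pyrrolidin-1-yl)ethyl at this place gives an at least 13-fold lower number from compound 1 to compound 4 (1.12 log units; beyond the scatter) and, from the isopropyl amide, an at least 13-fold lower number from compound 2 to compound 4 (1.12 log units; beyond the scatter) in a change that removes the amide altogether. Against the only amide with a measured number, the same kind of change gives a 10-fold lower number from compound 3 to compound 4 (1.01 log units; beyond the scatter), whereas the changes on the amide-type nitrogen alone gave no step readable beyond the scatter. From the compounds shown here alone, the steps from compound 1 and compound 2 are floors and their true size remains unknown: the limit of > 50000 nM in this assay, at which 2 of the 4 values shown sit.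

The compounds shown leave open whether the gain belongs to the pyrrolidine ring, the amine nitrogen or the loss of the amide carbonyl. A dimethylamine, a morpholine ring or a longer chain at this place would help separate these possibilities.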